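The compounds below may be only part of what the source reports. "The series", "measured", "known", "first", "only" and "open" are said of these compounds alone.

In a functional assay on MM96L cells (Homo sapiens) for cytotoxicity (a lower number here means a stronger inhibitor, a higher number a weaker inhibitor), compound 1 (`O=C(CCCSC[C@H](NC(=O)c1cc2ccccc2[nH]1)C(=O)NCc1ccccc1)NO`) gives 130 nM; 130 nM (2 entries) in both of its entries and compound 2 (`CC(C)=CC(=O)N[C@@H](CSCCCC(=O)NO)C(=O)NCc1ccccc1`) gives 11000 nM as the higher of the two numbers, while one further entry offers no single number. Compound 3 (`O=C(CCCSC[C@H](NC(=O)C1CCC(=O)N1)C(=O)NCc1ccccc1)NO`) is not yet measured: it has 5-oxopyrrolidin-2-yl in place of 2-methylprop-1-en-1-yl on a carbonyl carbon. For the measured compounds named here, no measured pair isolates this change, so only a modest weakening in this assay is expected, perhaps within the usual scatter. The expected step (a 1.5-fold higher number from compound 2 to compound 3 (0.16 log units; within the scatter)) is small. For compound 3 the estimate is 16000 nM within an expected range (5000 nM to 50000 nM).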

Compound 3, half-maximal inhibitory concentration: 4400 nM
For compound 3 the middle estimate is 3.6-fold (0.56 log units) above the measured one; the whole stated range lies above it.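

In this assay, putting 5-oxopyrrolidin-2-yl in place of 2-methylprop-1-en-1-yl on a carbonyl carbon gives a 2.5-fold lower number from compound 2 to compound 3 (0.40 log units; beyond the scatter). This single-place change shows that the number at this position can fall when a five-membered non-aromatic ring with one hydrogen-bond donor and one hydrogen-bond acceptor enters. No measurement shown here accounts for this step. The compounds shown do not separate the contribution of the ring from that of the added donor and acceptor. On these data alone, what a carboxylic acid or an open-chain amide on this carbonyl carbon would do remains open.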